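This account rests on a few compounds, and the source may have more. Where it says the series, first, only, none or still open, it means among the compounds named here.

Compound 1 `N#Cc1ccc2nc(Nc3ccc(Oc4ccccc4)cc3)[nH]c2c1`: in an assay on isolated protein for inhibition of casein kinase I isoform alpha (Homo sapiens) (a higher number here means a weaker inhibitor, a lower number a stronger inhibitor), compound 1 gives 8820 nM.
Compound 2 `N#Cc1ccc2nc(Nc3ccc(-c4cccnc4F)cc3)[nH]c2c1`: in this assay compound 2 gives 4670 nM.
Compound 3 `Cn1cc(-c2ccc(Nc3nc4ccc(C#N)cc4[nH]3)cc2)cn1`: in this assay compound 3 gives 3540 nM.

Among the compounds with values here, compound 3 holds the lowest of these three numbers, but its gap to compound 2 lies within the scatter; only the step of a 2.5-fold lower number from compound 1 to compound 3 (0.40 log units; beyond the scatter) lies beyond it. Compound 4 `Cc1ccc(Nc2nc3ccc(C#N)cc3[nH]2)cc1` differs from compound 3 in one place: methyl in place of 1-methyl-1H-pyrazol-4-yl on an aromatic carbon. Within the data shown here, no measured step swaps a ring for a plain methyl at this position. Among the measured compounds shown here, the steps that bear on it, a 2.5-fold lower number from compound 1 to compound 3 (0.40 log units; beyond the scatter) and a 1.3-fold lower number from compound 2 to compound 3 (0.12 log units; within the scatter), exchange one ring-bearing group for another and remain small. For compound 4 a somewhat higher number is expected, a 2.3-fold higher number from compound 3 to compound 4 (0.35 log units; beyond the scatter), a modest step at most, since the change removes the ring carried by every measured compound. The estimate for compound 4 in this assay is 8000 nM, with a range from 3000 nM to 25000 nM.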

Compound 4, half-maximal inhibitory concentration: 19700 nM
Compound 4: the middle estimate sits 2.5-fold (0.39 log units) below what was measured; the range from low to high includes it.
By their numbers in this assay, from the lowest: compounds 3, 2 and 1 (each within the scatter of the next, the first and the last beyond it); then compound 4.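

Until now every compound carried a ring at this position, and exchanging one ring-bearing group for another changed little. In this assay the steps to methyl, a 5.6-fold higher number from compound 3 to compound 4 (0.75 log units; beyond the scatter) and a 4.2-fold higher number from compound 2 to compound 4 (0.63 log units; beyond the scatter) and a 2.2-fold higher number from compound 1 to compound 4 (0.35 log units; beyond the scatter) all lie beyond the scatter, so each of the three ring-bearing groups gives a lower number than methyl does. No measured evidence here explains this difference.

From the compounds shown here alone, what an amine or a morpholine ring would give at this position stays open. So does whether a longer chain without a ring would behave like methyl or like the ring-bearing groups.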